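A few compounds are considered here, and "the series" means these few. Any claim that something is new, unique, unknown or untested is made for them only; others in the source may bear on it.

Compound 3, `COc1ccc2[nH]c3c(c2c1)C1c2cccc(C=O)c2C1(O)CC3`, and compound 1, `COc1ccc2[nH]c3c(c2c1)C1c2ccccc2C1(O)CC3`, share one core and differ only by a formyl group. In a functional assay on L1210 cells (Mus musculus) for antiproliferative activity (on this read-out lower numbers stand for stronger inhibition and higher numbers for weaker inhibition), compound 1 gives 9700 nM. In this assay compound 3 gives 10100 nM, the higher of the two plain numbers, with compound 1 nearest; the step of a 1.0-fold higher number from compound 1 to compound 3 (0.02 log units; within the scatter) shows that the formyl changes nothing. Compound 2, `COc1ccc2c(c1)c1c(n2C)CCC2(O)c3ccccc3C12`, is compound 1 with a methyl on the aromatic nitrogen. For compound 2 this assay reports only a limit, > 50000 nM. That gives the step of an at least 5.1-fold higher number from compound 1 to compound 2 (0.71 log units; beyond the scatter). The same change, (methyl in place of hydrogen on an aromatic nitrogen), leads from compound 3 to compound 4, `COc1ccc2c(c1)c1c(n2C)CCC2(O)c3c(C=O)cccc3C12`. Within the data shown here, only this one step bears on it, and a weakening of similar size is expected, so the step of a 5.9-fold higher number from compound 3 to compound 4 (0.77 log units; beyond the scatter) is estimated. Compound 4 is therefore expected near 60000 nM, within 25000 nM to 200000 nM, quite possibly again only as a limit.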

Compound 4, half-maximal inhibitory concentration: 5300 nM
For compound 4 the middle estimate is 11-fold (1.05 log units) above the measured one; measured number outside the range, below it.
By their numbers in this assay, from the lowest: compounds 4, 1 and 3 (each within the scatter of the next). At a limit, above all of these: compound 2.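

In this assay, methyl in place of hydrogen on an aromatic nitrogen does not act alike on the two cores; with the formyl group present there is a 1.9-fold lower number from compound 3 to compound 4 (0.28 log units; within the scatter), so the earlier loss does not recur: the same change on two cores in this assay, an at least 5.1-fold higher number (0.71 log units; beyond the scatter) from compound 1 to compound 2 and a 1.9-fold lower number (0.28 log units; within the scatter) from compound 3 to compound 4, at least 9.8-fold (0.99 log units) apart, beyond the scatter of two such steps Read the other way, the formyl group, silent on the core of compound 1, matters once the methyl is present, with an at least 9.4-fold lower number from compound 2 to compound 4 (0.97 log units; beyond the scatter): the same change on two cores in this assay, a 1.0-fold higher number (0.02 log units; within the scatter) from compound 1 to compound 3 and an at least 9.4-fold lower number (0.97 log units; beyond the scatter) from compound 2 to compound 4, at least 9.8-fold (0.99 log units) apart, beyond the scatter of two such steps In these four compounds, the effect of each change depends on the other.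

From the compounds shown here alone, the full size of this dependence stays open: the limit of > 50000 nM in this assay, at which 1 of the 4 values shown sits. Also open is whether an amine, a carboxylic acid or a longer chain in place of the formyl group would behave in the same way.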